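A few compounds are considered here, and "the series" means these few. Any claim that something is new, unique, unknown or untested is made for them only; others in the source may bear on it.

Measured compounds:
compound 1 `CC(C)(Oc1ccccc1F)C1OCC(C/C=C\CCC(=O)O)C(c2cccnc2)O1` — 166 nM
compound 2 `CC(C)(Oc1ccccc1O)C1OCC(C/C=C\CCC(=O)O)C(c2cccnc2)O1` — 95.5 nM

The study follows the step from compound 2 to compound 3 `CC(C)(Cc1ccc(F)cc1C#N)C1OCC(C/C=C\CCC(=O)O)C(c2cccnc2)O1` in a functional assay for inhibition, with Homo sapiens as the target; on this read-out higher numbers stand for weaker binding and lower numbers for tighter binding. Within the data shown here, compound 2 has the lowest of the two numbers so far; its nearest neighbour is compound 1, and the step of a 1.7-fold lower number from compound 1 to compound 2 (0.24 log units; within the scatter) lies within the scatter, so the two compounds cannot be ordered on these data.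

Compound 3 differs from compound 2 by a group of 10 heavy atoms (8 carbon, 1 nitrogen, 1 fluorine; one six-membered aromatic ring of carbon only) in place of a group of 8 heavy atoms (6 carbon, 2 oxygen; one six-membered aromatic ring of carbon only), on a saturated chain carbon bound to two saturated chain carbons and a saturated ring carbon. Among the measured compounds shown here, the only measured step, a 1.7-fold lower number from compound 1 to compound 2 (0.24 log units; within the scatter), exchanges one substituent on the aromatic ring for another and leaves the link to the saturated chain carbon untouched; the change to compound 3 replaces the whole group and its link, so no measured step bears closely on it. For the measured compounds named here, the one step that exists shows that this assay moved little under a change on the aromatic ring, which gives weak grounds for expecting a small step here too, but the new group is larger and the uncertainty is wide.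

Compound 3 is therefore estimated at 190 nM, with a range of 45 nM to 800 nM. This estimate means a step of a 2.0-fold higher number from compound 2 to compound 3 (0.30 log units; within the scatter), expected to stay within the scatter.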

Compound 3, dissociation constant: 2.19 nM
Compound 3: the middle estimate sits 87-fold (1.94 log units) above what was measured; measured number below the stated range.
By their numbers in this assay, from the lowest: compound 3; then compounds 2 and 1 (each within the scatter of the next).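

In this assay, among these compounds, the position on a saturated chain carbon bound to two saturated chain carbons and a saturated ring carbon turns out to respond far more strongly than the single earlier step could show: replacing the whole group gives a 44-fold lower number from compound 2 to compound 3 (1.64 log units; beyond the scatter), and the same kind of replacement starting from the fluoro analogue gives a 76-fold lower number from compound 1 to compound 3 (1.88 log units; beyond the scatter). Both steps lie beyond the scatter, while the exchange of substituents on the aromatic ring between compound 1 and compound 2 does not, so compound 3 stands clearly apart from two compounds that cannot be ordered against each other. Nothing among the data shown accounts for the size of this change.

The change to compound 3 alters the link to the chain carbon and both ring substituents at once, so the compounds shown cannot say whether the ether oxygen's departure, the nitrile or the fluoro carries the effect. On these data alone, it also remains open whether the low number would hold with a methoxy group or a chloro in place of the nitrile, or with the ether oxygen restored to the link while the nitrile and fluoro stay.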